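Ethyl in place of trifluoromethyl on the amide aryl ring

The source may report more compounds than this note shows. Statements on the series, on what has been measured and on what is new or still open speak of the compounds shown alone.

Three compounds share one core and differ only in the group on the outer aromatic ring of the amide. Compound 1 `Cc1ccc(C(=O)Nc2cccc(-c3oc4cc(-c5ccc(F)cc5)ccc4c(=O)c3O)c2)cc1` carries a methyl there and in a functional assay on MCF7 cells (Homo sapiens) for antiproliferative activity, read by CCK-8 assay, with a stated time of 72 h (on this read-out lower numbers stand for stronger inhibition and higher numbers for weaker inhibition), compound 1 gives 2400 nM. Compound 2 `O=C(Nc1cccc(-c2oc3cc(-c4ccc(F)cc4)ccc3c(=O)c2O)c1)c1ccc(Cl)cc1` carries a chloro and in this assay compound 2 gives 4730 nM. Compound 3 `O=C(Nc1cccc(-c2oc3cc(-c4ccc(F)cc4)ccc3c(=O)c2O)c1)c1ccc(C(F)(F)F)cc1` carries a trifluoromethyl and in this assay compound 3 gives 32600 nM, the highest number of the three, so it is the weakest inhibitor shown.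

Compound 4 `CCc1ccc(C(=O)Nc2cccc(-c3oc4cc(-c5ccc(F)cc5)ccc4c(=O)c3O)c2)cc1` differs from compound 3 by ethyl in place of trifluoromethyl on an aromatic carbon. Going by the values given here, the steps that bear on it are those leading away from the methyl of compound 1: a 2.0-fold higher number from compound 1 to compound 2 (0.29 log units; within the scatter) and a 14-fold higher number from compound 1 to compound 3 (1.13 log units; beyond the scatter), together with a 6.9-fold higher number from compound 2 to compound 3 (0.84 log units; beyond the scatter). Ethyl resembles methyl far more than it does trifluoromethyl, so a return toward the number of compound 1 is expected, giving a large fall in this assay: an 11-fold lower number from compound 3 to compound 4 (1.04 log units; beyond the scatter) is the expected step. Compound 4 is therefore estimated at 3000 nM, within a range from 1000 nM to 10000 nM.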

Compound 4, half-maximal inhibitory concentration: 22800 nM
Compound 4: the middle estimate sits 7.6-fold (0.88 log units) below what was measured, and the stated range ends below it.
By their numbers in this assay, from the lowest: compounds 1 and 2 (each within the scatter of the next); then compounds 4 and 3 (each within the scatter of the next).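

In this assay, a single added carbon at this position matters: going from methyl to ethyl gives a 9.5-fold higher number from compound 1 to compound 4 (0.98 log units; beyond the scatter), and chloro to ethyl gives a 4.8-fold higher number from compound 2 to compound 4 (0.68 log units; beyond the scatter), while a 1.4-fold lower number from compound 3 to compound 4 (0.16 log units; within the scatter) lies within the scatter, so ethyl reads with trifluoromethyl and not with methyl. Among these four compounds, methyl and chloro form one group and ethyl and trifluoromethyl form another, so the high numbers do not depend on fluorine, which ethyl lacks. No measurement here accounts for this split.

Going by these compounds, it remains open whether a longer chain such as propyl or butyl would stay at the level of ethyl or shift further from it. On these data alone, how plain hydrogen, an amine or a carboxylic acid would read at this position is also open.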